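Sulfonamide benzoxazole series: hydroxyphenyl positional change, cytotoxicity outlook

The source may hold more compounds than are shown below. What is called first, only, known or untested is meant among the compounds shown, and "the series" means these compounds.

Measured so far:
compound 1 `Cc1ccccc1S(=O)(=O)Nc1ccc2oc(-c3ccccc3)nc2c1` — 57000 nM
compound 2 `O=S(=O)(Nc1ccc(-c2nc3ccccc3o2)cc1)c1ccccc1O` — > 100000 nM
compound 3 `COc1cccc(S(=O)(=O)Nc2ccc3oc(-c4ccccc4)nc3c2)c1` — 63000 nM

The read-out throughout is an ADME assay on HEK293 cells (Homo sapiens) for cytotoxicity, read by resazurin assay, with a stated time of 48 h; on this read-out higher numbers stand for lower toxicity in this test and lower numbers for higher toxicity in this test. Compound 1 gives 57000 nM and compound 3 gives 63000 nM in this assay. For compound 2, this assay returns only a limit, > 100000 nM, so no number is known for it; it sits at the limit of > 100000 nM in this assay, at which 1 of the 3 values shown sits.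

Within the data shown here, the one step between measured compounds that differ in one place is a 1.1-fold higher number from compound 1 to compound 3 (0.04 log units; within the scatter). It concerns an exchange of the aryl group on the sulfonyl sulfur, as does the change considered here, but on a core joined differently from that of compound 2.

Compound 4 `O=S(=O)(Nc1ccc(-c2nc3ccccc3o2)cc1)c1ccc(O)cc1` is not yet measured. It differs from compound 2 by 4-hydroxyphenyl in place of 2-hydroxyphenyl on a sulfonyl sulfur; the two have the same atoms, joined differently. Among the measured compounds shown here, the only measured exchange on the sulfonyl sulfur stayed within the scatter, so no step beyond the scatter is expected in this assay from compound 2 to compound 4, and a limit is again the likelier outcome. The value of compound 4 is estimated at 100000 nM, with a range from 40000 nM to 250000 nM, meaning an expected step of a number no higher from compound 2 to compound 4 (the limit leaves the size open).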

Compound 4, half-maximal cytotoxic concentration: > 100000 nM
Compound 4 was reported as a limit; the forecaster's own chance of this, stated with the estimate: 60%; the middle value lies on the limit itself.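

Compound 2 and compound 4 are both reported as limits in this assay, not as numbers, so no step can be read between them: the limit of > 100000 nM in this assay, at which 2 of the 4 values shown sit.

The compounds shown leave open what number either compound would give, and whether 4-hydroxyphenyl in place of 2-hydroxyphenyl on a sulfonyl sulfur changes the read-out at all.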